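The source may hold more compounds than are shown below. What is called first, only, known or untested is meant among the compounds shown, and "the series" means these compounds.

Of the compounds shown here, two have been tested so far. Compound 1 `CC(O)(C(=O)Nc1ccc(S(=O)(=O)c2ccccc2O)cc1)C(F)(F)F` gives 3090 nM in a functional assay (Cavia porcellus) with sulfonylurea receptors; K-ATP channels (Homo sapiens) as the target; a higher number here means a weaker inhibitor, a lower number a stronger inhibitor. Compound 2 `COc1cc(NC(=O)C(C)(O)C(F)(F)F)ccc1S(=O)(=O)c1ccccc1`, in which the hydroxy group on the phenylsulfonyl ring is gone and a methoxy group sits on the other ring, gives 5900 nM in this assay. The two numbers lie within the usual scatter of each other, so neither compound can be called the stronger inhibitor on this evidence.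

Compound 3 `CC(O)(C(=O)Nc1ccc(S(=O)(=O)c2ccccc2)c(C(F)(F)F)c1)C(F)(F)F` has not yet been measured. It differs from compound 2 by trifluoromethyl in place of methoxy on an aromatic carbon. For the measured compounds named here, no step between two measured compounds involves this kind of exchange, so there is nothing to lean on beyond the two numbers already in hand. With that in mind, only a modest shift is expected, most likely one that does not rise beyond the scatter in either direction. Compound 3 is therefore expected to give about 3500 nM in this assay, within a range from 900 nM to 14000 nM. The step of a 1.7-fold lower number from compound 2 to compound 3 (0.23 log units; within the scatter) is accordingly expected to be small.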

Compound 3, half-maximal inhibitory concentration: > 30000 nM
Compound 3 was reported as a limit (the forecaster's own chance of this, stated with the estimate: 5%); middle value at least 8.5-fold (0.93 log units) from the limit.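

At this position, ortho to a phenylsulfonyl group, trifluoromethyl in place of methoxy gives an at least 5.0-fold higher number from compound 2 to compound 3 (0.70 log units; beyond the scatter) in this assay. For the compounds shown here, this is the first step that can be read as one change in one place, and it shows that the group on this aromatic carbon can matter: the exchange makes compound 3 a clearly weaker inhibitor than compound 2. Compound 3 is reported only as a limit, > 30000 nM, so the step gives a smallest size and no exact one: the limit of > 30000 nM in this assay, at which 1 of the 3 values shown sits.

On these data alone, a single exchange cannot tell which difference between methoxy and trifluoromethyl matters, and it remains open whether a smaller or different group at this position, such as an amine, a nitrile or a chlorine atom, would keep the inhibition, lose it or improve on it. Compound 1 and compound 2 differ in more than one place, so the separate contributions of the hydroxy group on the phenylsulfonyl ring and of the methoxy group also remain unresolved.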